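The source may hold more compounds than are shown below. What is called first, only, known or untested is meant among the compounds shown, and "the series" means these compounds.

Measured in a physicochemical assay for lipophilicity, at pH 7.4; on this read-out higher numbers stand for higher lipophilicity and lower numbers for lower lipophilicity:
- compound 1 `COc1ccc2[nH]c(C)c(Cc3ccccc3)c(=O)c2c1`: 2.53
- compound 2 `CCCCCCCCCc1c(C)[nH]c2cc(OC)c(Cl)cc2c1=O`: 4.74
- compound 3 `COc1cc2[nH]c(C)c(C3CCCCC3)c(=O)c2cc1Cl`: 3.04

Compound 3, at 3.04, is the second highest of the three. Its gaps to compound 1 below and compound 2 above both lie beyond the scatter. Compound 4 `COc1cc2[nH]c(C)c(Br)c(=O)c2cc1Cl` has bromo in place of cyclohexyl on an aromatic carbon. For the measured compounds named here, no two measured compounds differ in only one place, so the data offer no direct guide to this change, and any forecast is tentative. A moderate fall in this assay, beyond the scatter, is expected, with an estimated step of a number 0.64 log units lower from compound 3 to compound 4 (beyond the scatter). For compound 4 the estimated value is 2.4, with an expected range of 1.9 to 3.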

Compound 4, distribution coefficient: 0
The estimate for compound 4 lay 2.40 log units above the measured number; the measured number lies below the stated range.
By their numbers in this assay, from the lowest: compound 4; then compound 1; then compound 3; then compound 2.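

For the compounds shown here, replacing cyclohexyl with bromo on this aromatic carbon gives the first single-change comparison at this position: in this assay the result is a number 3.04 log units lower from compound 3 to compound 4 (beyond the scatter) and counts as large. Going by these compounds alone, this shows that the group here can move the read-out strongly, which the earlier compounds could not show, since none of them differed in only one place. Nothing measured here accounts for the size of this step.

One step at this position cannot show how other groups would behave. An ethyl group, an amine or a carboxylic acid here could each fall anywhere relative to compound 3 and compound 4.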